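Taking a methyl off the ring of compound 2

The source may hold more compounds than are shown below. What is called first, only, known or untested is meant among the compounds shown, and "the series" means these compounds.

Compound 1 `Cc1nn(-c2cccc3cc(Cc4cccc(C(F)(F)F)c4)sc23)cc1C(=O)NCCO` opens this small set. In a physicochemical assay for solubility, read by HPLC, at pH 6.8 (on this read-out higher numbers stand for higher solubility and lower numbers for lower solubility), compound 1 gives only a limit of the assay, < 0.1 ug/mL. Compound 2 `COCCNC(=O)c1cn(-c2cccc3cc(Cc4cccc(C(F)(F)F)c4)sc23)nc1C` likewise gives only a limit in this assay, < 0.1 ug/mL. The step that the two limits leave unreadable from compound 1 to compound 2 cannot be read because both values sit at the limit of < 0.1 ug/mL in this assay, at which 2 of the 3 values shown sit. Compound 3 `Cc1c(C(=O)NCCO)c(CO)nn1-c1cccc2cc(Cc3cccc(C(F)(F)F)c3)sc12`, in contrast, gives 18 ug/mL. The change followed here leads from compound 2 to compound 4 `COCCNC(=O)c1cnn(-c2cccc3cc(Cc4cccc(C(F)(F)F)c4)sc23)c1`: hydrogen in place of methyl on an aromatic carbon. Within the data shown here, no measured step bears on this change, as the only one available is unreadable. Compound 2 stands at the limit, so only a rise could become visible. The expected step is a number no lower from compound 2 to compound 4 (the limit leaves the size open). Compound 4 is estimated at 0.1 ug/mL, with a range from 0.02 ug/mL to 0.5 ug/mL.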

Compound 4, solubility: < 0.08 ug/mL
Compound 4: no number, only a limit; the forecaster's own chance of this, stated with the estimate: 70%; middle value at least 1.2-fold (0.09 log units) away from the limit.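

Compound 2 and compound 4 both give only limits of the assay, and the step between them cannot be read. On these data alone, whether hydrogen in place of methyl on this aromatic carbon changes solubility at all stays open.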